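Swapping the aryl group once more: compound 2 to compound 3

A few compounds are considered here, and "the series" means these few. Any claim that something is new, unique, unknown or untested is made for them only; others in the source may bear on it.

In an ADME assay on microsomes from liver (Homo sapiens) for metabolic stability (a lower number here means slower removal, a higher number faster removal of the compound), compound 2 `CCOc1cc([C@](O)(CCN(C)C)[C@H](c2cccc(C)c2)c2cc3cc(Br)ccc3nc2OC)cc(OC)n1` gives 4.4 uL/min, and compound 1 `CCOc1cc([C@](O)(CCN(C)C)[C@@H](c2cc3cc(Br)ccc3nc2OC)c2cccc(OC)c2F)cc(OC)n1` gives 4.1 uL/min; the two numbers are within the scatter of each other. Among the measured compounds shown here, the only step measured so far at this position, a 1.1-fold higher number from compound 1 to compound 2 (0.03 log units; within the scatter), also changed the aryl group on that carbon. Compound 3 `CCOc1cc([C@](O)(CCN(C)C)[C@@H](c2cc3cc(Br)ccc3nc2OC)c2ccnc(OC)c2OC)cc(OC)n1` differs from compound 2 by 2,3-dimethoxypyridin-4-yl in place of 3-methylphenyl on a saturated chain carbon bound to an aromatic carbon and a saturated chain carbon. Because a 1.1-fold higher number from compound 1 to compound 2 (0.03 log units; within the scatter) lay within the scatter, a step of similar size is expected here, a 1.1-fold higher number from compound 2 to compound 3 (0.04 log units; within the scatter), with no clear direction. Compound 3 is therefore estimated at 4.8 uL/min, with a range from 2.4 uL/min to 9.6 uL/min.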

Compound 3, intrinsic clearance in a liver preparation (reported as CLH), per the amount of preparation that the assay uses: 3.8 uL/min
The estimate for compound 3 lay 1.3-fold (0.10 log units) above the measured number, within the range that was stated.
By their numbers in this assay, from the lowest: compounds 3, 1 and 2 (each within the scatter of the next).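

In this assay, 2,3-dimethoxypyridin-4-yl brings a hetero atom into the aromatic ring at this position, and the number barely shifts: there is a 1.2-fold lower number from compound 2 to compound 3 (0.06 log units; within the scatter), and a 1.1-fold lower number from compound 1 to compound 3 (0.03 log units; within the scatter). All three groups therefore give numbers within the scatter of one another, even though this ring differs from 3-methylphenyl in its atoms and its hydrogen-bond acceptors. No available evidence bears on this result.

Still open, from the compounds shown here alone, is whether a group on this carbon could shift the number beyond the scatter. A carboxylic acid or an amine on the ring, or a cyclohexyl group in place of the aromatic ring, would test that.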